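One aryl swap on a shared core

The source may report more compounds than this note shows. Statements on the series, on what has been measured and on what is new or still open speak of the compounds shown alone.

Of the compounds shown here, two sharing the same core have been tested in an assay on isolated protein for inhibition of Amine oxidase [flavin-containing] B (Homo sapiens); a higher number here means a weaker inhibitor, a lower number a stronger inhibitor. Compound 1 `C#CCNC1CCc2c(SCCc3cccc(C)c3)cccc21` carries a 3-methylphenyl group on the chain beyond the sulfur, and in this assay compound 1 gives 0.35 nM, the lower of the two numbers recorded so far, which makes compound 1 the stronger inhibitor of the pair. Compound 2 `C#CCNC1CCc2c(SCCc3cccc(C(F)(F)F)c3)cccc21` differs from it only by a trifluoromethyl in place of the methyl on an aromatic carbon; in this assay compound 2 gives 3720 nM. That single exchange produces an 11000-fold higher number from compound 1 to compound 2 (4.03 log units; beyond the scatter).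

Compound 3 `C#CCNC1CCc2c(SCCc3ccc(Cl)cc3)cccc21` has not yet been measured. It differs from compound 1 by 4-chlorophenyl in place of 3-methylphenyl on a saturated chain carbon, two bonds along the chain from a sulfur. Among the measured compounds shown here, no measured step covers this exact change: the only recorded step, from compound 1 to compound 2, swaps one substituent for another rather than exchanging the whole aryl group. That step does show that this assay can react very strongly to a change on this ring, so a step of some size is plausible, but its direction cannot be read from compound 2 alone. Compound 3 is therefore expected to give 20 nM in this assay, with a wide range from 1 nM to 600 nM. This estimate corresponds to an expected step of a 57-fold higher number from compound 1 to compound 3 (1.76 log units; beyond the scatter).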

Compound 3, half-maximal inhibitory concentration: 10800 nM
Beside the measured number, compound 3's estimate is 540-fold (2.73 log units) below it; the measured number lies above the stated range.
By their numbers in this assay, from the lowest: compound 1; then compound 2; then compound 3.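

In this assay the exchange of the whole aryl group gives a 31000-fold higher number from compound 1 to compound 3 (4.49 log units; beyond the scatter), so the sharp sensitivity seen with trifluoromethyl is not confined to that one group. The two aryl groups match in everything counted here, with 7 heavy atoms each, one six-membered aromatic ring of carbon only and no hydrogen-bond donors or acceptors, so these counts do not separate the strong inhibitor from the weak one. Both departures from 3-methylphenyl shown on this core raise the number far beyond the scatter, and neither compound 2 nor compound 3 comes close to compound 1.

No measurement available here explains why the number climbs so steeply. Compound 3 changes both the substituent and its place on the ring in a single move, so 3-chlorophenyl and 4-methylphenyl would be needed to pull those two changes apart, while a plain phenyl would show whether the methyl of compound 1 is needed at all.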